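Trimming one methoxy group from compound 2

The source may report more compounds than this note shows. Statements on the series, on what has been measured and on what is new or still open speak of the compounds shown alone.

Measured so far:
- compound 1 `COc1ccc(-c2cc(/C=C/C(=O)c3ccc(N)cc3)[nH]n2)cc1`, 2070 nM
- compound 2 `COc1cc(-c2cc(/C=C/C(=O)c3ccc(N)cc3)[nH]n2)cc(OC)c1OC`, 1800 nM

Both were tested in a functional assay on NCI-H460 cells (Homo sapiens) for inhibition, read by sulforhodamine B assay, with a stated time of 48 h; on this read-out higher numbers stand for weaker inhibition of growth and lower numbers for stronger inhibition of growth. Compound 2 has the lowest of the two numbers, and compound 1 is its nearest neighbour; the gap between them is within the scatter, so the two values cannot be told apart on this read-out. Compound 3 `COc1ccc(-c2cc(/C=C/C(=O)c3ccc(N)cc3)[nH]n2)cc1OC` is not yet measured. It differs from compound 2 in one place: hydrogen in place of methoxy on an aromatic carbon, so one methoxy group is removed while the other two remain. Among the measured compounds shown here, no step between measured compounds changes only this position, so there is no direct precedent. Since compound 1, which carries a single methoxy group, and compound 2, which carries three, give numbers that sit within the scatter of each other in this assay, compound 3, which sits between them in the count of methoxy groups, is expected to land close to both, with a step from compound 2 of about a 1.1-fold higher number from compound 2 to compound 3 (0.02 log units; within the scatter), not beyond the scatter. The estimate for compound 3 is therefore 1900 nM, with a range from 900 nM to 4000 nM.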

Compound 3, concentration for 50% growth inhibition: 2030 nM
For compound 3 the middle estimate is 1.1-fold (0.03 log units) below the measured one, and the stated range covers the measured number.
By their numbers in this assay, from the lowest: compounds 2, 3 and 1 (each within the scatter of the next).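

In this assay, putting hydrogen in place of methoxy on an aromatic carbon, at the place ortho to a methoxy group and meta to a large group, gives a 1.1-fold higher number from compound 2 to compound 3 (0.05 log units; within the scatter) and so produces no difference that this read-out can detect. Among the compounds shown here, the reverse kind of change, methoxy in place of hydrogen on an aromatic carbon, gives a 1.0-fold lower number from compound 1 to compound 3 (0.01 log units; within the scatter) and also stays within the scatter, so these two single-place steps offer the first direct look at this change, which the earlier pair could not provide on its own. No measurement shown here accounts for how small these steps are.

Hydrogen and methoxy are the only groups compared at this position, so it remains open whether a different group there, such as a hydroxyl, a carboxylic acid or a longer chain like ethoxy, would shift the number beyond the scatter. The compounds also leave open whether this position would tolerate such changes equally well with the other parts of the shared core altered, and whether the same would hold in other cells.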